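Adding a Second Fluoro: Cytotoxicity of Compound 3

The source may hold more compounds than are shown below. What is called first, only, known or untested is meant among the compounds shown, and "the series" means these compounds.

Measured so far:
- compound 1, `Cc1nc(C(NC(=O)C(=O)Nc2ccc(F)cc2)C2CCCCN2)sc1CCO`: 109000 nM
- compound 2, `Cc1nc(C(NC(=O)C(=O)Nc2ccc(Cl)c(F)c2)C2CCCCN2)sc1CO`: 77800 nM

Both compounds were tested in an ADME assay on MT2 cells (Homo sapiens) for cytotoxicity, read by XTT assay, with a stated time of 4 days; on this read-out higher numbers stand for lower toxicity in this test and lower numbers for higher toxicity in this test. Compound 1 gives 109000 nM, the highest of the two numbers, and compound 2 gives 77800 nM; the gap between them lies within the usual scatter, so neither can be called less toxic than the other. Compound 3, `Cc1nc(C(NC(=O)C(=O)Nc2ccc(F)c(F)c2)C2CCCCN2)sc1CCO`, has not been measured yet. It differs from compound 1 in one place: fluoro in place of hydrogen on an aromatic carbon. Among the compounds with values here, no step between two measured compounds exists here to guide the expectation, so the change is judged on its small size alone. From compound 1 to compound 3 the step in this assay is expected to be essentially none beyond the scatter, a 1.1-fold lower number from compound 1 to compound 3 (0.06 log units; within the scatter). Compound 3 is therefore expected to give about 95000 nM in this assay, within a range of 45000 nM to 200000 nM.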

Compound 3, half-maximal cytotoxic concentration: > 78200 nM
Compound 3: no number, only a limit (the forecaster's own chance of this, stated with the estimate: 25%); the middle value is on the limit's open side.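

In this assay compound 3 gives > 78200 nM, which is a limit and not a number. Within the data shown here, no step from compound 1 to compound 3 can be read from it. The compounds shown leave open whether fluoro in place of hydrogen on an aromatic carbon shifts cytotoxicity at all, and by how much.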